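This account rests on a few compounds, and the source may have more. Where it says the series, first, only, none or still open, it means among the compounds named here.

Compound 1 `Cc1ccccc1CNC(=O)n1cnc2ccccc21`: 1.37 h
Compound 2 `Cc1ccccc1CNC(=O)n1c(N)nc2ccccc21`: 0.45 h
Compound 3 `CCCCCCNC(=O)n1nnc2ccccc21`: > 2 h (a limit of the assay, not a number)

In a physicochemical assay for metabolic stability, read by HPLC, at pH 4.5, tested at 10 uM (a lower number here means that the compound disappears faster, a higher number that the compound lasts longer), compound 2 gives the lowest of the two actual numbers, 0.45 h. Among the measured compounds shown here, the one measured step, a 3.0-fold lower number from compound 1 to compound 2 (0.48 log units; beyond the scatter), puts amino in place of hydrogen on an aromatic carbon and lies beyond the scatter.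

Compound 4 `Cc1cccc(CNC(=O)n2c(N)nc3ccccc32)c1` has the same atoms as compound 2, joined differently: 3-methylphenyl in place of 2-methylphenyl on a saturated chain carbon bound to an amide-type nitrogen. Here 3-methylphenyl takes the place of 2-methylphenyl on a saturated chain carbon bound to an amide-type nitrogen.

For the measured compounds named here, no measured step touches this group. The change a 3.0-fold lower number from compound 1 to compound 2 (0.48 log units; beyond the scatter) lies at another place, so it sets no expected size here, and no shift beyond the scatter is expected in this assay. The expected outcome is no change at the digits printed from compound 2 to compound 4 (within the scatter). For compound 4 the estimate is 0.45 h, with an expected range of 0.25 h to 0.8 h.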

Compound 4, half-life: 0.45 h
The estimate for compound 4 equals the measured number at the digits printed, and the stated range covers the measured number.
By their numbers in this assay, from the lowest: compounds 2 and 4 (each within the scatter of the next); then compound 1. At a limit, above all of these: compound 3.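

In this assay, 3-methylphenyl in place of 2-methylphenyl gives no change at the digits printed from compound 2 to compound 4 (within the scatter), so on the core of compound 2 the half-life reads the same with either group. Among the compounds shown here, this is the first reading at this group, as the only earlier step lay at another place. Nothing measured here says why the two groups read alike. On these data alone, whether the same holds on the core of compound 1 stays open. So does the outcome with other groups at this place, such as 4-methylphenyl or a phenyl ring carrying a carboxylic acid or an amine.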